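Silyl ether cyclopentenone with a dimethyl-methoxyphenyl ring

The source may hold more compounds than are shown below. What is called first, only, known or untested is meant among the compounds shown, and "the series" means these compounds.

Compound 1, `COc1ccc(C2=C(c3cc(OC)c(OC)c(OC)c3)C(=O)C(OC(C)=O)C2)cc1Cl`, < 1 ug/mL; compound 2, `COC(=O)c1cc(C2=C(c3cc(OC)c(OC)c(OC)c3)C(=O)CC2O[SiH2]C(C)(C)C)ccc1OC`, > 100 ug/mL; compound 3, `COc1ccc(C2=C(c3cc(OC)c(OC)c(OC)c3)C(=O)C(OC(C)=O)C2)cc1O`, 6 ug/mL.

The three measured compounds share a core carrying a 3,4,5-trimethoxyphenyl group on one double-bonded ring carbon and a second aromatic ring on the other. In an ADME assay on L132 cells (Homo sapiens) for cytotoxicity, read by MTT assay, with a stated time of 72 h (on this read-out higher numbers stand for weaker inhibition and lower numbers for stronger inhibition), compound 1 gives < 1 ug/mL, which is a limit of the assay and not a number (the limit of < 1 ug/mL in this assay, at which 1 of the 3 values shown sits). Compound 3 gives 6 ug/mL in this assay. Going by the values given here, the one step that can be read between measured compounds, an at least 6.0-fold higher number from compound 1 to compound 3 (0.77 log units; beyond the scatter), concerns a change on the second aromatic ring of the acetate series.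

In this assay compound 2 gives > 100 ug/mL, which is also a limit and not a number (the limit of > 100 ug/mL in this assay, at which 1 of the 3 values shown sits). Compound 2 thus stands at the weak end of what the three values show.

Compound 4, `COc1cc(C2=C(c3cc(C)c(OC)c(C)c3)C(O[SiH2]C(C)(C)C)CC2=O)cc(OC)c1OC`, keeps the silyl ether of compound 2 and differs from it by 4-methoxy-3,5-dimethylphenyl in place of 4-methoxy-3-(methoxycarbonyl)phenyl on a double-bonded ring carbon. No measured step follows this change: the only step shown, an at least 6.0-fold higher number from compound 1 to compound 3 (0.77 log units; beyond the scatter), swaps a chloro for a hydroxy on a different series, and compound 2 itself sits at a limit, so the direction of any step from compound 2 to compound 4 cannot be read from the numbers in hand. The measurement of compound 4 in this assay is what would settle it.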

Compound 4, half-maximal inhibitory concentration: > 100 ug/mL
Compound 4 ended at the assay's limit; the forecaster's own chance of this, stated with the estimate: 50%; at least 1.6-fold (0.22 log units) between middle value and limit.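

In this assay compound 4 gives > 100 ug/mL, which is a limit of the assay and not a number. Compound 2 stands at the same kind of limit, so no step from compound 2 to compound 4 can be read: the limit of > 100 ug/mL in this assay, at which 2 of the 4 values shown sit.

The compounds shown leave open whether 4-methoxy-3,5-dimethylphenyl and 4-methoxy-3-(methoxycarbonyl)phenyl differ at all in this silyl ether series.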